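The source may report more compounds than this note shows. Statements on the series, on what has been measured and on what is new or still open speak of the compounds shown alone.

Measured so far in an ADME assay on Vero cells (Chlorocebus sabaeus) for cytotoxicity, read by MTT assay, with a stated time of 72 h; on this read-out higher numbers stand for weaker inhibition and lower numbers for stronger inhibition:

Compound 1, `CCCCNc1nc(=O)c2cc(C(F)(F)F)cc([N+](=O)[O-])c2s1`, gives > 100000 nM, which is a limit of the assay.
Compound 2, `O=c1nc(NC2CCCC2)sc2c([N+](=O)[O-])cc(C(F)(F)F)cc12`, gives > 100000 nM, which is a limit of the assay.
Compound 3, `O=c1nc(N2CCCC2)sc2c([N+](=O)[O-])cc(C(F)(F)F)cc12`, gives > 100000 nM, which is a limit of the assay.

Compound 3 therefore stands at the same limit as the other two, and no number places it above or below them. Compound 4, `CC1CCN(c2nc(=O)c3cc(C(F)(F)F)cc([N+](=O)[O-])c3s2)CC1`, differs from it by one change: 4-methylpiperidin-1-yl in place of pyrrolidin-1-yl on an aromatic carbon. The measured steps that touch the same aromatic carbon are a step that the two limits leave unreadable from compound 1 to compound 3 and a step that the two limits leave unreadable from compound 2 to compound 3, and the step that the two limits leave unreadable from compound 1 to compound 2 is no more readable; all three rest on (the limit of > 100000 nM in this assay, at which 3 of the 3 values shown sit). Nothing among these steps gives a direction or a size, so the change to 4-methylpiperidin-1-yl is expected to leave compound 4 at or near the limit as well. On that basis compound 4 is estimated at 150000 nM in this assay, with a range from 50000 nM to 500000 nM. That estimate amounts to a step that the limit leaves unreadable from compound 3 to compound 4, which is not expected to be resolved beyond the scatter.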

Compound 4, half-maximal inhibitory concentration: > 100000 nM
Compound 4 ended at the assay's limit; the forecaster's own chance of this, stated with the estimate: 85%; the middle value is on the limit's open side.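

In this assay compound 4 gives > 100000 nM, which is a limit of the assay. Within the data shown here, no step from compound 1, compound 2 or compound 3 to compound 4 can be read: the limit of > 100000 nM in this assay, at which 4 of the 4 values shown sit. The compounds shown leave open whether the groups on that aromatic carbon differ at all in this assay.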